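Changing the Aryl Group on the Imine Nitrogen

This account rests on a few compounds, and the source may have more. Where it says the series, first, only, none or still open, it means among the compounds named here.

In an assay on isolated protein for binding affinity to corticotropin-releasing factor receptor 1 (Homo sapiens) (a higher number here means a weaker inhibitor, a lower number a stronger inhibitor), compound 2 `CC(=O)/C(=N\c1ccc(Cl)cc1)NNc1ccccc1C(F)(F)F` gives > 10000 nM, which is a limit of the assay rather than a measured number (the limit of > 10000 nM in this assay, at which 1 of the 2 values shown sits). By comparison, compound 1 `CC(=O)/C(=N\c1cccc(C)c1)NNc1ccccc1Cl` gives 115 nM in this assay. Compound 3 `CC(=O)/C(=N\c1cccc(C)c1)NNc1ccccc1C(F)(F)F` is compound 2 with 3-methylphenyl in place of 4-chlorophenyl on a double-bonded nitrogen. Among the compounds with values here, no measured pair isolates this change, so the step is an estimate: a gain in strength, with an expected step of an at least 10-fold lower number from compound 2 to compound 3 (1.00 log units; beyond the scatter). Compound 3 is expected near 1000 nM, within 150 nM to 10000 nM, since it carries the 3-methylphenyl of compound 1 with its 115 nM.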

Compound 3, inhibition constant: 1420 nM
Compound 3: the middle estimate sits 1.4-fold (0.15 log units) below what was measured; low and high end bracket the measured number.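

Placing 3-methylphenyl instead of 4-chlorophenyl on the double-bonded nitrogen brings binding into the measurable range (an at least 7.0-fold lower number from compound 2 to compound 3 (0.84 log units; beyond the scatter)), so the aryl group here matters. Compound 2 stands at a limit of the assay, so this step has only a lower bound: the limit of > 10000 nM in this assay, at which 1 of the 3 values shown sits. With 3-methylphenyl kept, the other aryl group also matters, as trifluoromethyl in place of chloro on an aromatic carbon weakens binding (a 12-fold higher number from compound 1 to compound 3 (1.09 log units; beyond the scatter)).

Still open, on these data alone, is whether the chlorine leaving or the methyl entering drives the first step. As far as these compounds go, how a phenyl carrying an amine would behave on this nitrogen also remains unknown.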